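From 3,5-Dimethylphenyl to 2-Nitrophenyl on a Shared Core

The compounds below may be only part of what the source reports. "The series", "measured", "known", "first", "only" and "open" are said of these compounds alone.

Of the compounds shown here, three have been measured in a functional assay on BJAB cells (Homo sapiens) for antiproliferative activity, with a stated time of 4 days; a higher number here means that more compound is needed for the effect, a lower number that less compound is needed. Compound 1 `Cc1ccccc1-c1c(C)nn(-c2nc(-c3ccc(Cl)c(Cl)c3)c(SC(C)C)s2)c1C(=O)O` gives 5500 nM, compound 2 `Cc1cc(C)cc(-c2c(C)nn(-c3nc(-c4ccc(Cl)c(Cl)c4)c(SC(C)C)s3)c2C(=O)O)c1` gives 2700 nM, and compound 3 `Cc1c(-c2cc(Cl)cc(Cl)c2)c(C(=O)O)nn1-c1nc(-c2ccncc2)c(SC(C)C)s1`, which differs from both in more than one place, is reported as "not active" (no number reported). Among the compounds with values here, compound 2 therefore stands lowest of the two numbers, with compound 1 as its nearest neighbour, and the single connecting step a 2.0-fold lower number from compound 1 to compound 2 (0.31 log units; beyond the scatter) is modest but beyond the scatter.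

Compound 4 `Cc1nn(-c2nc(-c3ccc(Cl)c(Cl)c3)c(SC(C)C)s2)c(C(=O)O)c1-c1ccccc1[N+](=O)[O-]` has not yet been measured. It differs from compound 2 in one place: 2-nitrophenyl in place of 3,5-dimethylphenyl on an aromatic carbon. Within the data shown here, only the step of a 2.0-fold lower number from compound 1 to compound 2 (0.31 log units; beyond the scatter) bears on this change, and the move to compound 4 runs the other way, from 3,5-dimethylphenyl back to a phenyl with a single substituent, as in compound 1, though now a nitro group rather than a methyl. Nothing measured tells how a 2-nitrophenyl behaves here. Compound 4 is expected to sit close to compound 1 at 5500 nM, so a modest rise a 2.2-fold higher number from compound 2 to compound 4 (0.35 log units; beyond the scatter) is expected. Compound 4 is estimated at 6000 nM, with a range from 2500 nM to 15000 nM.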

Compound 4, half-maximal effective concentration: 4700 nM
Estimate against measurement, compound 4: 1.3-fold (0.11 log units) above; the range from low to high includes it.
By their numbers in this assay, from the lowest: compounds 2, 4 and 1 (each within the scatter of the next, the first and the last beyond it).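

Compound 1 and compound 2 had shown this position on the shared core only with methyl-bearing phenyl groups, whereas compound 4 places a 2-nitrophenyl there, a group with nitrogen, oxygen and hydrogen-bond acceptors. In this assay, the exchange of 3,5-dimethylphenyl for 2-nitrophenyl gives a 1.7-fold higher number from compound 2 to compound 4 (0.24 log units; within the scatter), and nitro in place of methyl gives a 1.2-fold lower number from compound 1 to compound 4 (0.07 log units; within the scatter), so neither step separates the compounds. Introducing the nitro group therefore leaves compound 4 within the scatter of both neighbours, even though those two stand apart by a 2.0-fold lower number from compound 1 to compound 2 (0.31 log units; beyond the scatter).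

As far as these compounds go, whether an amine or a methoxy group in place of the nitro would also leave the number undisturbed remains open. Nothing available explains why nitro and methyl read alike at this position.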